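Benzyloxy for diethylamino: notes on compound 3

The source may report more compounds than this note shows. Statements on the series, on what has been measured and on what is new or still open speak of the compounds shown alone.

Measured in a functional assay on A-427 cells (Homo sapiens) for cytotoxicity, read by colorimetric assay and MTT assay (on this read-out higher numbers stand for weaker inhibition and lower numbers for stronger inhibition), so far
compound 1 `COc1ccc(-c2cc3c(OC)ccc(OC)c3nc2O)cc1` gives 10000 nM
compound 2 `CCN(CC)C(=O)Cn1c(=O)c(-c2ccc(OC)cc2)cc2c(OC)cc(OC)cc21` gives 10000 nM

Compound 2 stands level with compound 1, with nothing between them beyond the scatter. Compound 3 `COc1ccc(-c2cc3c(OC)cc(OC)cc3n(CC(=O)OCc3ccccc3)c2=O)cc1` carries benzyloxy in place of diethylamino on a carbonyl carbon and awaits measurement. For the measured compounds named here, no measured pair shows this change, so its size cannot be read from the data. The expectation rests only on compound 2 at 10000 nM and is for no step beyond the scatter, with a slight lean towards stronger inhibition. The estimate means a 1.4-fold lower number from compound 2 to compound 3 (0.15 log units; within the scatter) as the expected step in this assay for now. Compound 3 is estimated at 7000 nM with an expected range from 2500 nM to 15000 nM as the likely span.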

Compound 3, half-maximal inhibitory concentration: 10000 nM
Compound 3: middle estimate off by 1.4-fold (0.15 log units), on the low side; low and high end bracket the measured number.
By their numbers in this assay, from the lowest: compounds 1, 2 and 3 (each within the scatter of the next).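

In this assay benzyloxy in place of diethylamino on a carbonyl carbon gives no change at the digits printed from compound 2 to compound 3 (within the scatter) as the first step readable in the series. At this position, then, a group with one six-membered aromatic ring and one hydrogen-bond acceptor replaces a ringless group with no acceptor, and the printed number stays the same. No measurement shown here bears on the reason for this result.

Still open, going by these compounds, is whether a carboxylic acid or a morpholine group on that carbonyl carbon would separate from these values. Also open, on these data alone, is whether any group at this position moves the number at all.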